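Tetrazole for Carboxy: Expecting Compound 4

The source may hold more compounds than are shown below. What is called first, only, known or untested is meant among the compounds shown, and "the series" means these compounds.

Of the compounds shown here, three have been measured in an assay on membranes from lung (Cavia porcellus) for binding affinity to cysteinyl leukotriene receptor (Homo sapiens); a lower number here means a stronger inhibitor, a higher number a weaker inhibitor. Compound 1 `CC(CCCC(=O)O)c1cccc(OCc2ccc3ccccc3n2)c1` gives 90 nM. Compound 2 `c1ccc2nc(COc3ccc(OCCCc4nnn[nH]4)cc3)ccc2c1` gives 69 nM, a value within the usual scatter of compound 1, so the two cannot be set apart. Compound 3 `O=C(O)CCCOc1ccc(OCc2ccc3ccccc3n2)cc1` gives 1200 nM, a clearly weaker result than either.

Compound 3 and compound 2 share a core and differ in one place, (1H-tetrazol-5-yl in place of carboxy on a saturated chain carbon, three bonds along the chain from an oxygen on an aromatic ring). This change made a large step: a 17-fold lower number from compound 3 to compound 2 (1.24 log units; beyond the scatter). Compound 1 has a different core from compound 3; the difference between the two cores is not broken down here.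

Compound 4 `CC(CCCc1nnn[nH]1)c1cccc(OCc2ccc3ccccc3n2)c1` has not yet been measured. It is related to compound 1 by 1H-tetrazol-5-yl in place of carboxy on a saturated chain carbon, four bonds along the chain from an aromatic carbon. For the measured compounds named here, this is the same kind of change as the one from compound 3 to compound 2, though the surroundings differ: in compound 2 the new group sits three bonds along the chain from an oxygen on an aromatic ring, while in compound 4 it sits four bonds along the chain from an aromatic carbon. Going by the values given here, because the step of a 17-fold lower number from compound 3 to compound 2 (1.24 log units; beyond the scatter) was large, a sizeable step is expected here too, though with only one earlier example and a different core, the size is uncertain. The expected step from compound 1 to compound 4 in this assay is a 9.0-fold lower number from compound 1 to compound 4 (0.95 log units; beyond the scatter). Compound 4 is therefore estimated at 10 nM, with a likely range from 3 nM to 40 nM.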

Compound 4, inhibition constant: 31 nM
The estimate for compound 4 lay 3.1-fold (0.49 log units) below the measured number; the measured number falls inside the stated range.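

In this assay, putting 1H-tetrazol-5-yl in place of carboxy on the core of compound 1 gives a 2.9-fold lower number from compound 1 to compound 4 (0.46 log units; beyond the scatter), so the number falls on this core as it did on the core of compound 3. The direction of the change therefore carries over in both examples shown, but its size does not: the two steps differ by more than repeat measurements would explain: the same change on two cores in this assay, a 17-fold lower number (1.24 log units; beyond the scatter) from compound 3 to compound 2 and a 2.9-fold lower number (0.46 log units; beyond the scatter) from compound 1 to compound 4, 6.0-fold (0.78 log units) apart, beyond the scatter of two such steps. This does not show which feature of the two cores sets the size of the step, since they differ from each other in more than one place, and two examples cannot establish a rule for the whole series.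

The compounds shown leave open how the step would look on a third core, and whether it would lie nearer the larger or the smaller of these two results. They also leave open what a longer or shorter chain carrying the 1H-tetrazol-5-yl group would give, and how an acylsulfonamide in the same place would compare with either carboxy or 1H-tetrazol-5-yl.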